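Swapping ethoxy for ethylamino on a carbonyl carbon

This account rests on a few compounds, and the source may have more. Where it says the series, first, only, none or still open, it means among the compounds named here.

- Compound 1 `O=C(N[C@@H](CCC(=O)N1CCN(c2cccc(NC3=NCC(O)CN3)c2)CC1)C(=O)O)OCc1ccccc1` gives 3.5 nM
- Compound 2 `O=C(N[C@@H](CCC(=O)N1CCN(c2cccc(NC3=NCCCCN3)c2)CC1)C(=O)O)OCc1ccccc1` gives 1.7 nM
- Compound 3 `CCOC(=O)N[C@@H](CCC(=O)N1CCN(c2cccc(NC3=NCCCN3)c2)CC1)C(=O)O` gives 2.1 nM

In a functional assay (muscle tissue) for inhibition, with Homo sapiens as the target (a lower number here means a stronger inhibitor, a higher number a weaker inhibitor), compound 3 gives 2.1 nM and this value lies within the scatter of both compound 1 and compound 2. Among the compounds with values here, the only measured step in this small set is a 2.1-fold lower number from compound 1 to compound 2 (0.31 log units; beyond the scatter) and it lies just beyond the scatter.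

Compound 4 `CCNC(=O)N[C@@H](CCC(=O)N1CCN(c2cccc(NC3=NCCCN3)c2)CC1)C(=O)O` differs from compound 3 in one place, with ethylamino in place of ethoxy on a carbonyl carbon. Put one bond further out, ethoxycarbonyl becomes ethylcarbamoyl.

Within the data shown here, no measured step covers this change. The step of a 2.1-fold lower number from compound 1 to compound 2 (0.31 log units; beyond the scatter) alters a different group, so it offers only a rough sense of how far one edit can move the numbers here, and that move was modest. The expectation therefore starts from compound 3 at 2.1 nM and no step beyond the scatter is expected in this assay in either direction. The estimated step is a 1.4-fold higher number from compound 3 to compound 4 (0.15 log units; within the scatter) and it is a small one. For compound 4 the expected value is 3 nM with an estimated range from 0.9 nM to 12 nM as its limits. Among the measured compounds shown here, the range is kept wide, since no measurement yet speaks to this swap.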

Compound 4, half-maximal inhibitory concentration: > 10 nM
Compound 4 gave a limit, no number; the forecaster's own chance of this, stated with the estimate: 3%; middle value at least 3.3-fold (0.52 log units) away from the limit.
By their numbers in this assay, from the lowest: compounds 2, 3 and 1 (each within the scatter of the next, the first and the last beyond it). At a limit, above all of these: compound 4.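

Within the data shown here, this is the first measured change at the carbamate end of the series, since the earlier step, a 2.1-fold lower number from compound 1 to compound 2 (0.31 log units; beyond the scatter), altered a different group. Replacing ethoxy with ethylamino on a carbonyl carbon whose other neighbour is an amide-type nitrogen gives an at least 4.7-fold higher number from compound 3 to compound 4 (0.67 log units; beyond the scatter), so this position does not accept every group of the same size. The two groups have the same count of heavy atoms, yet they differ in one atom, oxygen against nitrogen, and ethylamino has a hydrogen-bond donor where ethoxy has none, so a small edit here can matter more than its size suggests.

In this assay compound 4 gives a limit and not a number, which means the full size of the step stays unknown: the limit of > 10 nM in this assay, at which 1 of the 4 values shown sits.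

The compounds shown also leave open whether the nitrogen itself or the hydrogen on it goes with the change, and dimethylamino on the same carbonyl carbon, which has no hydrogen on that nitrogen, would help to separate the two.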